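Swapping a Diene Chain for Heptyl in Compound 2

A few compounds are considered here, and "the series" means these few. Any claim that something is new, unique, unknown or untested is made for them only; others in the source may bear on it.

In a functional assay on cells (Platelet, Oryctolagus cuniculus) for inhibition, read by turbidimetry, with a stated time of 3 min, tested at 100 ug/mL (a higher number here means a weaker effect of the compound at the concentration tested, a lower number a stronger effect), compound 1 `CCCCCCC(=O)CC/C=C/C=C/C(=O)NCC(C)C` gives 0% and compound 2 `CC/C=C/C/C=C\CC/C=C/C=C/C(=O)NCC(C)(C)O` gives 0%, so the two stand level and are together the lowest of the three numbers. Compound 3 `COc1ccc(-c2oc3c(OC)c(OC)cc(O)c3c(=O)c2O)cc1` gives 73.3% in this assay, a reading far above compound 2 and beyond the scatter. Compound 4 `CCCCCCCCC/C=C/C=C/C(=O)NCC(C)(C)O` has not yet been measured. It differs from compound 2 in one place: heptyl in place of hepta-1,4-dien-1-yl on a saturated chain carbon, two bonds along the chain from a double-bonded chain carbon. Among the compounds with values here, no pair of measured compounds shows what such a change does here, so the expectation rests only on compound 2 and on compound 1, whose 0% likewise shows no effect at the concentration tested. The expected step of a number 5 percentage points higher from compound 2 to compound 4 (within the scatter) lies within the scatter. Compound 4 is estimated at 5%, within 0% to 25%.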

Compound 4, a percentage reported as activity, at one concentration (the size of the read-out at that concentration, not a potency): 0%
Compound 4: the middle estimate sits 5 percentage points above what was measured, and the stated range covers the measured number.
By their numbers in this assay, from the lowest: compounds 1, 2 and 4 (each within the scatter of the next); then compound 3.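

In this assay, within the data shown here, putting heptyl in place of hepta-1,4-dien-1-yl gives no change at the digits printed from compound 2 to compound 4 (within the scatter), the first change in a single place that can be read. At this position, on a saturated chain carbon, two bonds along the chain from a double-bonded chain carbon, losing the two double bonds of that chain therefore leaves the reading where it was. Nothing available here accounts for this result. Going by these compounds, whether a carboxylic acid, an amine or a longer chain at the same place would move the reading remains open.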